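A few compounds are considered here, and "the series" means these few. Any claim that something is new, unique, unknown or untested is made for them only; others in the source may bear on it.

In an ADME assay on THP-1 cells (Homo sapiens) for cytotoxicity, read by resazurin assay, with a stated time of 48 h (a lower number here means a stronger inhibitor, a higher number a weaker inhibitor), compound 3 `CN(C)c1ccc(-c2ccc(Cn3cccc(O)c3=O)cc2)cc1` gives > 10 ug/mL, which is a limit and not a number. Compound 2 `Cc1ccc(-c2ccc(Cn3cccc(O)c3=O)cc2)cc1` gives > 10 ug/mL, also a limit. Compound 1 `N#Cc1ccc(-c2ccc(Cn3cccc(O)c3=S)cc2)cc1` gives > 10 ug/mL, again a limit. Together these make up (the limit of > 10 ug/mL in this assay, at which 3 of the 3 values shown sit). Going by the values given here, the one measured step is a step that the two limits leave unreadable from compound 2 to compound 3, so it offers no size to carry forward.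

Compound 4 `CN(C)c1ccc(-c2ccc(Cn3cccc(O)c3=S)cc2)cc1` differs from compound 3 in a single place, on a saturated chain carbon bound to an aromatic carbon: a group of 8 heavy atoms (5 carbon, 1 nitrogen, 1 oxygen, 1 sulfur; one six-membered aromatic ring with 1 hetero atom) in place of a group of 8 heavy atoms (5 carbon, 1 nitrogen, 2 oxygen; one six-membered aromatic ring with 1 hetero atom), on a saturated chain carbon bound to an aromatic carbon. In short, a sulfur enters where an oxygen leaves. Among the compounds with values here, compound 1 carries the same sulfur-containing group, but no oxygen counterpart of it has been measured, so this swap has not been seen directly.

With only limits to go on, no clear direction can be expected in this assay, and the expected change is a step that the limit leaves unreadable from compound 3 to compound 4. Compound 4 is estimated at 15 ug/mL, with an expected range from 6 ug/mL to 40 ug/mL.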

Compound 4, half-maximal inhibitory concentration: > 10 ug/mL
Compound 4 ended at the assay's limit; the forecaster's own chance of this, stated with the estimate: 70%; the middle value does not contradict the limit.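

In this assay, no size can be read for the steps joining compound 4 to compound 3 or compound 1, because every compound shown sits at a limit: the limit of > 10 ug/mL in this assay, at which 4 of the 4 values shown sit.

The compounds shown leave open whether a sulfur entering where an oxygen leaves changes cytotoxicity at all.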